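The source may hold more compounds than are shown below. What is called first, only, known or untested is meant among the compounds shown, and "the series" means these compounds.

In an ADME assay on Raji cells (Homo sapiens) for cytotoxicity, read by luminescence, with a stated time of 72 h (on this read-out lower numbers stand for an effect already at smaller amounts and higher numbers for an effect only at larger amounts of compound), compound 3 (`CCOC(=O)c1c(-c2cccc(OC)c2)[nH]c2cc(Cl)c(OC)cc2c1=O`) gives > 21500 nM as a limit, not a number. Compound 2 (`CCOC(=O)c1c(-c2cccc(-c3ccccc3)c2)[nH]c2cc(Cl)c(OC)cc2c1=O`) gives > 21500 nM as a limit too. Compound 1 (`CCOC(=O)c1c(-c2cccc(Oc3ccccc3)c2)[nH]c2cc(OC)c(OC)cc2c1=O`), which already carries phenoxy, gives > 21500 nM as a limit too. Everything so far is the limit of > 21500 nM in this assay, at which 3 of the 3 values shown sit, with no number yet. Compound 4 (`CCOC(=O)c1c(-c2cccc(Oc3ccccc3)c2)[nH]c2cc(Cl)c(OC)cc2c1=O`) has phenyl in place of methyl on an oxygen on an aromatic ring relative to compound 3. The nearest measured step (a step that the two limits leave unreadable from compound 2 to compound 3) is methoxy in place of phenyl and gives no size to carry over. An estimated step that the limit leaves unreadable from compound 3 to compound 4 is expected in this assay with no firm direction behind it. Compound 4 is estimated at 30000 nM within 15000 nM to 60000 nM and is expected to be reported only as a limit.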

Compound 4, half-maximal effective concentration: > 21500 nM
Compound 4 gave a limit, no number (the forecaster's own chance of this, stated with the estimate: 85%); the middle value is on the limit's open side.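

No step can be read between compound 4 and compound 1, compound 2 or compound 3 in this assay, as each value is a limit: the limit of > 21500 nM in this assay, at which 4 of the 4 values shown sit.

Where any of these four compounds would give an actual number in this assay stays open.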